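The source may report more compounds than this note shows. Statements on the series, on what has been measured and on what is new or still open speak of the compounds shown alone.

Measured compounds in a functional assay on Jurkat cells (Homo sapiens) for inhibition; on this read-out lower numbers stand for stronger inhibition and higher numbers for weaker inhibition:
- compound 1 `COC(=O)c1cc(OCC(=O)[C@H](CC(=O)O)NC(=O)[C@@H](NC(=O)COc2cccc3ccccc23)C(C)C)no1` gives 71000 nM
- compound 2 `CC(C)[C@H](NC(=O)COc1cccc2ccccc12)C(=O)N[C@@H](CC(=O)O)C(=O)CSc1nnnn1-c1ccccc1` gives 153000 nM
- compound 3 `CC(C)[C@H](NC(=O)COc1cccc2ccccc12)C(=O)N[C@@H](CC(=O)O)C(=O)CSc1nnnn1C` gives only a limit, > 200000 nM

Compound 1 holds the lowest of the two numbers actually reported; the nearest is compound 2, at a step of a 2.2-fold higher number from compound 1 to compound 2 (0.33 log units; beyond the scatter). The step of an at least 2.8-fold higher number from compound 1 to compound 3 (0.44 log units; beyond the scatter) cannot be sized fully because the limit of > 200000 nM in this assay, at which 1 of the 3 values shown sits, caps compound 3. Between the two tetrazolyl compounds the step of an at least 1.3-fold higher number from compound 2 to compound 3 (0.11 log units; that floor lies within the scatter) adds little.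

Compound 4 `CC(C)[C@H](NC(=O)COc1cccc2ccccc12)C(=O)N[C@@H](CC(=O)O)C(=O)CSc1nc2ccccc2o1` differs from compound 1 as follows: (1,3-benzoxazol-2-yl)sulfanyl in place of (5-(methoxycarbonyl)-1,2-oxazol-3-yl)oxy on a saturated chain carbon bound to a carbonyl carbon. Both measured steps that replace the same group with a heteroaryl sulfanyl group went to higher numbers, modest in size. The entering group here is again a heteroaryl sulfanyl, so a step of similar direction and size is expected in this assay, with little reason to expect a number lower than that of compound 1.

Compound 4 is therefore estimated at 150000 nM, within 70000 nM to 300000 nM, which means an expected step of a 2.1-fold higher number from compound 1 to compound 4 (0.32 log units; beyond the scatter).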

Compound 4, half-maximal inhibitory concentration: > 200000 nM
Compound 4: only a limit was reported; the forecaster's own chance of this, stated with the estimate: 30%; middle value at least 1.3-fold (0.12 log units) away from the limit.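

In this assay compound 4 gives > 200000 nM, which is a limit and not a number. With an at least 2.8-fold higher number from compound 1 to compound 4 (0.44 log units; beyond the scatter), all three heteroaryl sulfanyl groups on the saturated chain carbon bound to a carbonyl carbon now read higher than the (5-(methoxycarbonyl)-1,2-oxazol-3-yl)oxy group, and the pattern extends from the tetrazolyl groups to (1,3-benzoxazol-2-yl)sulfanyl, with no compound shown going against it. The other readable step is an at least 1.3-fold higher number from compound 2 to compound 4 (0.11 log units; that floor lies within the scatter), so no order is claimed for that pair, and the step between compound 3 and compound 4 cannot be read: the limit of > 200000 nM in this assay, at which 2 of the 4 values shown sit.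

Each step away from compound 1 changes the linking oxygen to sulfur and the ring together, so the two changes remain unseparated. A (1,3-benzoxazol-2-yl)oxy group or a phenoxy group at this place would be the open comparison.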